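Side-chain amine variation against a cytotoxicity read-out

This account rests on a few compounds, and the source may have more. Where it says the series, first, only, none or still open, it means among the compounds named here.

Measured compounds:
Compound 1 `O=C(CCC1CCNCC1)Nc1nc2ccc(C(=O)c3ccccc3)cc2[nH]1` — in an ADME assay on HL-60 cells (Homo sapiens) for cytotoxicity, read by resazurin assay, with a stated time of 72 h (on this read-out higher numbers stand for an effect only at larger amounts of compound and lower numbers for an effect already at smaller amounts), compound 1 gives > 30000 nM, a limit of the assay.
Compound 2 `CN1CCC(CCn2c(N)nc3ccc(C(=O)c4ccccc4)cc32)CC1` — in this assay compound 2 gives > 30000 nM, a limit of the assay.
Compound 3 `Nc1nc2ccc(C(=O)c3ccccc3)cc2n1C[C@@H]1CCCN1` — in this assay compound 3 gives > 30000 nM, a limit of the assay.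

Compound 3 therefore stands at the upper edge of what this assay reports, with no number of its own; the other two measured compounds sit at the same edge, as summarised by the limit of > 30000 nM in this assay, at which 3 of the 3 values shown sit. Among the measured compounds shown here, the one step between measured compounds that differ in a single place, a step that the two limits leave unreadable from compound 2 to compound 3, cannot be sized, since both ends are limits.

Compound 4 `Nc1nc2ccc(C(=O)c3ccccc3)cc2n1CCN1CCCCC1` is not yet measured. It differs from compound 3 by (piperidin-1-yl)methyl in place of pyrrolidin-2-yl on a saturated chain carbon bound to an aromatic nitrogen. For the measured compounds named here, no measured step bears on this change with a readable size, so nothing in the data supports an expectation of movement beyond the scatter in this assay. The step expected from compound 3 to compound 4 is a step that the limit leaves unreadable from compound 3 to compound 4, which is an estimate pinned to a limit. For compound 4 the expected value in this assay is 50000 nM, within a range from 20000 nM to 150000 nM, and most likely the assay again reports only a limit.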

Compound 4, half-maximal effective concentration: > 30000 nM
Compound 4: only a limit was reported (the forecaster's own chance of this, stated with the estimate: 85%); the middle value is on the limit's open side.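

Compound 4, like compound 2 and compound 3, is reported only as a limit, so neither step to compound 4 can be read. Whether the side-chain amines shown differ at all in this assay stays open, with every value at one edge: the limit of > 30000 nM in this assay, at which 4 of the 4 values shown sit.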